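Phenyl Added to the Five-Membered Ring of Compound 2

The source may hold more compounds than are shown below. What is called first, only, known or untested is meant among the compounds shown, and "the series" means these compounds.

For the measured compounds named here, in a functional assay on MCF7 cells (Homo sapiens) for inhibition, read by sulforhodamine B assay, with a stated time of 72 h (a lower number here means a stronger inhibitor of growth, a higher number a weaker inhibitor of growth), compound 2 `O=S(=O)(Nc1cc(-c2cnc3[nH]ncc3c2)cnc1Cl)c1ccccc1` gives 7400 nM, the higher of the two numbers measured so far, and the gap to compound 1 `O=S(=O)(Nc1cc(-c2cnc3[nH]cc(-c4ccncc4)c3c2)cnc1Cl)c1ccccc1F`, which gives 2500 nM in this assay, lies beyond the usual scatter. Compound 3 `O=S(=O)(Nc1cc(-c2cnc3[nH]nc(-c4ccccc4)c3c2)cnc1Cl)c1ccccc1` differs from compound 2 by phenyl in place of hydrogen on an aromatic carbon. Going by the values given here, no measured pair shows this same change, so the direction rests on expectation alone: compound 3 is expected to move toward a lower number by a modest step of a 2.5-fold lower number from compound 2 to compound 3 (0.39 log units; beyond the scatter). Compound 3 is therefore estimated at 3000 nM, within the range 800 nM to 12000 nM.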

Compound 3, concentration for 50% growth inhibition: 7370 nM
The estimate for compound 3 lay 2.5-fold (0.39 log units) below the measured number; the range from low to high includes it.
By their numbers in this assay, from the lowest: compound 1; then compounds 3 and 2 (each within the scatter of the next).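

In this assay, placing phenyl in place of hydrogen on the aromatic carbon of the five-membered ring gives compound 3 a number that cannot be told apart from that of compound 2 (a 1.0-fold lower number from compound 2 to compound 3 (0.00 log units; within the scatter)). This carbon therefore accepts one six-membered aromatic ring of carbon only, with neither gain nor loss of growth inhibition in this assay. Nothing given here accounts for this result.

On these data alone, whether an amine or a carboxylic acid on the same carbon would separate from compound 2 remains open. So does whether phenyl would give the same result on the core of compound 1.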